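Ester chain length and cytotoxicity in one series

The source may report more compounds than this note shows. Statements on the series, on what has been measured and on what is new or still open speak of the compounds shown alone.

Compound 1 `CCCCCCOC(=O)CCC(=O)N1CCN(CCCOc2cc3c(Nc4ccc(F)c(Cl)c4)ncnc3cc2OC)CC1`, compound 2 `CCCCCCCOC(=O)CCC(=O)N1CCN(CCCOc2cc3c(Nc4ccc(F)c(Cl)c4)ncnc3cc2OC)CC1` and compound 3 `CCCCCCCCCCCOC(=O)CCC(=O)N1CCN(CCCOc2cc3c(Nc4ccc(F)c(Cl)c4)ncnc3cc2OC)CC1` share one core and differ only in the length of the ester chain. In a functional assay on A549 cells (Homo sapiens) for cytotoxicity, read by MTT assay, with a stated time of 24 h, tested at 20 uM (a higher number here means a weaker effect of the compound at the concentration tested, a lower number a stronger effect), compound 1 gives 85.1%, compound 2 gives 79.9% and compound 3 gives 85.2%. The step of a number 5.2 percentage points lower from compound 1 to compound 2 (within the scatter) corresponds to methyl in place of hydrogen on a saturated chain carbon, six bonds along the chain from an oxygen next to a carbonyl group. The cores of compound 1 and compound 3 differ by pentyl in place of hydrogen on a saturated chain carbon, six bonds along the chain from an oxygen next to a carbonyl group. Compound 4 `CCCCCCCCCCCCOC(=O)CCC(=O)N1CCN(CCCOc2cc3c(Nc4ccc(F)c(Cl)c4)ncnc3cc2OC)CC1` is not yet measured; it differs from compound 3 by methyl in place of hydrogen on a saturated chain carbon, ten or more bonds along the chain from an oxygen next to a carbonyl group, the same kind of change as between compound 1 and compound 2. Because compound 3 gives 85.2% in this assay and every step among compounds 1, 2 and 3 lies within the scatter, the step from compound 3 to compound 4 is expected as a number 2.2 percentage points lower from compound 3 to compound 4 (within the scatter). Compound 4 is expected to give 83%, estimated between 72% and 93%.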

Compound 4, a percentage reported as activity, at one concentration (the size of the read-out at that concentration, not a potency): 86.8%
Compound 4: the middle estimate sits 3.8 percentage points below what was measured; measured number inside the range.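

In this assay, methyl in place of hydrogen gives a number 1.6 percentage points higher from compound 3 to compound 4 (within the scatter), and this step matches the earlier one on the other core: the same change on two cores in this assay, a number 5.2 percentage points lower (within the scatter) from compound 1 to compound 2 and a number 1.6 percentage points higher (within the scatter) from compound 3 to compound 4, 6.8 percentage points apart, within the scatter of two such steps. Pentyl in place of hydrogen, giving a number 6.9 percentage points higher from compound 2 to compound 4 (within the scatter), likewise matches its earlier counterpart: the same change on two cores in this assay, a number 0.1 percentage points higher (within the scatter) from compound 1 to compound 3 and a number 6.9 percentage points higher (within the scatter) from compound 2 to compound 4, 6.8 percentage points apart, within the scatter of two such steps. Within the data shown here, with hexyl in place of hydrogen also giving only a number 1.7 percentage points higher from compound 1 to compound 4 (within the scatter), these ester chain changes carry across the cores without a readable effect, but this does not show that a real effect transfers, since no step rises above the scatter.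

Open, as far as these compounds go, is whether an ethyl ester, or an amine or carboxylic acid at the end of the ester chain, would move the number beyond the scatter. A single concentration also leaves potency undefined.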